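A few compounds are considered here, and "the series" means these few. Any claim that something is new, unique, unknown or untested is made for them only; others in the source may bear on it.

Measured in an assay on CHO cells for antagonist activity at transient receptor potential cation channel subfamily V member 1 (Homo sapiens), read by FLIPR; on this read-out lower numbers stand for stronger inhibition and higher numbers for weaker inhibition:
compound 1 `CC(C(=O)NCc1ccc(C(F)(F)F)cc1N1CCN(C2CCCCC2)CC1)c1ccc(NS(C)(=O)=O)c(F)c1` gives 13.8 nM;
compound 2 `Cc1cccc(N2CCN(c3cc(C(F)(F)F)ccc3CNC(=O)C(C)c3ccc(NS(C)(=O)=O)c(F)c3)CC2)c1` gives 1.8 nM;
compound 3 `CCCCCCOc1cc(C(C)(F)F)ccc1CNC(=O)C(C)c1ccc(NS(C)(=O)=O)c(F)c1` gives 0.8 nM.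

Compound 1 stands highest of the three numbers in this assay; compound 2 lies nearest and compound 3 furthest from it. Compound 4 `COc1ccc(CSc2cc(C(F)(F)F)ccc2CNC(=O)C(C)c2ccc(NS(C)(=O)=O)c(F)c2)cc1` differs from compound 1 in one place: (4-methoxybenzyl)sulfanyl in place of 4-cyclohexylpiperazin-1-yl on an aromatic carbon. For the measured compounds named here, no measured step covers this exchange directly. Going by the values given here, the one recorded step, a 7.7-fold lower number from compound 1 to compound 2 (0.88 log units; beyond the scatter), shows that changing the group on that aromatic carbon can move the number well beyond the scatter, and compound 3, which carries a hexyloxy group there instead of the piperazine, gives the lowest number of the set, though it also differs elsewhere. Compound 4 is therefore expected to give a lower number than compound 1, a step of about a 5.5-fold lower number from compound 1 to compound 4 (0.74 log units; beyond the scatter). Compound 4 is estimated at 2.5 nM, with a range from 0.6 nM to 10 nM.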

Compound 4, inhibition constant: 2.3 nM
Estimate against measurement, compound 4: 1.1-fold (0.04 log units) above, within the range that was stated.
By their numbers in this assay, from the lowest: compound 3; then compounds 2 and 4 (each within the scatter of the next); then compound 1.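

Replacing 4-cyclohexylpiperazin-1-yl with (4-methoxybenzyl)sulfanyl on this aromatic carbon gives a 6.0-fold lower number from compound 1 to compound 4 (0.78 log units; beyond the scatter) and so shows that a low number here does not depend on a piperazine ring or on any nitrogen in the group. Compound 2 at 1.8 nM and compound 4 at 2.3 nM lie within the usual scatter of each other, although their groups differ in the atom attached to the ring. Nothing available explains the change in the number.

Going by these compounds, what stays open is whether the sulfur itself matters, as a 4-methoxybenzyloxy group would test. On these data alone, it is also open how a small group such as methoxy or a primary amine would fare on this carbon.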